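A few compounds are considered here, and "the series" means these few. Any claim that something is new, unique, unknown or untested is made for them only; others in the source may bear on it.

Compound 2 `c1cc(CNC2CCN(CCCc3c[nH]c4ccc(-n5cnnc5)cc34)CC2)co1` gives 7.1 nM in an assay on CHO cells for agonist activity at 5-hydroxytryptamine receptor 1D (Homo sapiens), read by GTPgammaS binding (on this read-out lower numbers stand for an effect already at smaller amounts and higher numbers for an effect only at larger amounts of compound), the lowest of the two numbers in hand; compound 1 `c1ccc2c(c1)CCC2NC1CCN(CCCc2c[nH]c3ccc(-n4cnnc4)cc23)CC1` gives 25 nM, and the step of a 3.5-fold lower number from compound 1 to compound 2 (0.55 log units; beyond the scatter) changes only the group on the amine nitrogen. Compound 3 `CC(=O)Nc1ccc(CNC2CCN(CCCc3c[nH]c4ccc(-n5cnnc5)cc34)CC2)cc1` differs from compound 2 at that same spot: 4-acetamidophenyl in place of furan-3-yl on a saturated chain carbon bound to an amine nitrogen. Going by the values given here, only the one measured step bears on this change, and it was modest, so a modest shift toward a higher number is expected here, since compound 1 gave 25 nM. Compound 3 is therefore estimated at 15 nM, between 4 nM and 60 nM, a step of a 2.1-fold higher number from compound 2 to compound 3 (0.32 log units; beyond the scatter).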

Compound 3, half-maximal effective concentration: 5 nM
Estimate against measurement, compound 3: 3.0-fold (0.48 log units) above; measured number inside the range.
By their numbers in this assay, from the lowest: compounds 3 and 2 (each within the scatter of the next); then compound 1.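

In this assay, the swap of furan-3-yl for 4-acetamidophenyl on a saturated chain carbon bound to an amine nitrogen leaves the number where it was, a 1.4-fold lower number from compound 2 to compound 3 (0.15 log units; within the scatter), so a five-membered and a six-membered aromatic ring both fit this place. The measured gap to the 2,3-dihydro-1H-inden-1-yl group holds for the new group too, a 5.0-fold lower number from compound 1 to compound 3 (0.70 log units; beyond the scatter). No measurement at hand accounts for these numbers.

Going by these compounds, it remains open whether an amine or a carboxylic acid in place of the acetamido group, or a longer chain to the amine nitrogen, would keep this level.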